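Two isoflavone ether acids and an ester against the enzyme

A few compounds are considered here, and "the series" means these few. Any claim that something is new, unique, unknown or untested is made for them only; others in the source may bear on it.

The study compares three compounds sharing one core. Compound 1 `O=C(O)CCCCCCCCCCCCCCCOc1ccc2c(=O)c(-c3ccc(O)cc3)coc2c1` carries a long chain ending in a carboxylic acid, compound 2 `CCOC(=O)CCCCOc1ccc2c(=O)c(-c3ccc(O)cc3)coc2c1` a shorter chain ending in an ethyl ester, and compound 3 `O=C(O)CCCCCCCOc1ccc2c(=O)c(-c3ccc(O)cc3)coc2c1` a chain of intermediate length ending in a carboxylic acid. In an assay (Cricetulus griseus) for inhibition of aldehyde dehydrogenase, mitochondrial (Homo sapiens) (on this read-out lower numbers stand for stronger inhibition and higher numbers for weaker inhibition), compound 1 reaches only a limit of the assay, > 9000 nM, and gives no number. In this assay, for the measured compounds named here, compound 2 gives 240 nM, the single numerical value among the measured compounds. The other measured value, that of compound 1, is a limit (the limit of > 9000 nM in this assay, at which 1 of the 2 values shown sits).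

From compound 2 to compound 3 the change is 3-carboxypropyl in place of ethoxycarbonyl on a saturated chain carbon, four bonds along the chain from an oxygen on an aromatic ring. Going by the values given here, no measured pair shows this step directly, so its size is uncertain. Compound 3 is expected to sit in this assay at 2000 nM, within a range from 400 nM to 9000 nM, with a real chance that only a limit is reported. The step of an 8.3-fold higher number from compound 2 to compound 3 (0.92 log units; beyond the scatter) is thus estimated to weaken inhibition beyond the usual scatter, an expectation that rests on compound 2 at 240 nM. The result for compound 1, which reaches only a limit of the assay at > 9000 nM, points the same way.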

Compound 3, half-maximal inhibitory concentration: 40 nM
Compound 3: the middle estimate sits 50-fold (1.70 log units) above what was measured, outside the stated range (below it).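

Replacing ethoxycarbonyl with 3-carboxypropyl on a saturated chain carbon, four bonds along the chain from an oxygen on an aromatic ring, gives a 6.0-fold lower number from compound 2 to compound 3 (0.78 log units; beyond the scatter) in this assay, which shows that a chain ending in a carboxylic acid can go with stronger inhibition than the shorter chain ending in an ethyl ester. The two acids also show that the chain length matters with the acid end held constant: the shorter chain of compound 3 compared with the long chain of compound 1 gives an at least 220-fold lower number from compound 1 to compound 3 (2.35 log units; beyond the scatter). The size of that second step rests on a limit for compound 1, not on a number: the limit of > 9000 nM in this assay, at which 1 of the 3 values shown sits.

The step from compound 2 to compound 3 changes chain length and chain end together, and the compounds shown do not tell how much of it belongs to each, which an ethyl ester on the chain of compound 3 could separate. Also open, as far as these compounds go, are the chain length at which inhibition falls away among the acids and whether an amide or an amine at the chain end would keep it.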